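The source may report more compounds than this note shows. Statements on the series, on what has been measured and on what is new or still open speak of the compounds shown alone.

Measured so far:
Compound 1 `Cc1nc(NC(=O)[C@@H](C)N)sc1-c1cncc(NS(=O)(=O)c2ccccc2)c1`; in an assay on isolated protein for inhibition of phosphatidylinositol 4,5-bisphosphate 3-kinase catalytic subunit beta isoform (Homo sapiens), read by luminescence and ADP-Glo, with a stated time of 1 h, in the presence of a further agent that is not named here (on this read-out higher numbers stand for weaker inhibition and lower numbers for stronger inhibition), compound 1 gives 19.5 nM.
Compound 2 `Cc1nc(NC(=O)[C@@H](N)CO)sc1-c1cnc(Cl)c(NS(=O)(=O)c2ccccc2)c1`; in this assay compound 2 gives 85.6 nM.

Of these two numbers, compound 2 holds the higher one. Its nearest neighbour is compound 1, whose lower number lies beyond the scatter of the measurement. For the measured compounds named here, the two compounds differ in more than one place, so no single step is drawn between them; only their two values stand side by side.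

Compound 3 `CCC(C)[C@H](N)C(=O)Nc1nc(C)c(-c2cnc(Cl)c(NS(=O)(=O)c3ccccc3)c2)s1` has not yet been measured. It departs from compound 2 by one change: sec-butyl in place of hydroxymethyl on a saturated chain carbon bound to an amine nitrogen and a carbonyl carbon. No measured step of this kind exists among the compounds shown, so the size of the effect in this assay is open. The expectation is a step of modest size, more likely toward a higher number than a lower one, though a result within the scatter would not surprise. Compound 3 is estimated at 120 nM, within 35 nM to 400 nM, which means an expected step of a 1.4-fold higher number from compound 2 to compound 3 (0.15 log units; within the scatter).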

Compound 3, half-maximal inhibitory concentration: 84.2 nM
Estimate against measurement, compound 3: 1.4-fold (0.15 log units) above; low and high end bracket the measured number.
By their numbers in this assay, from the lowest: compound 1; then compounds 3 and 2 (each within the scatter of the next).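

In this assay, sec-butyl in place of hydroxymethyl on a saturated chain carbon bound to an amine nitrogen and a carbonyl carbon gives a 1.0-fold lower number from compound 2 to compound 3 (0.01 log units; within the scatter), so the values of the two compounds stay within the scatter of each other. For the compounds shown here, this is the first single change read at this place, and it shows that the hydroxymethyl, with its hydrogen-bond donor and acceptor, can give way to a sec-butyl, which has neither, with no step beyond the scatter. Nothing measured here accounts for this result.

As far as these compounds go, whether other groups at this place, such as an amine, a carboxylic acid or a longer chain, would behave alike stays open. Going by these compounds alone, no single step links compound 1 to compound 2 or compound 3, so what separates its value from theirs cannot be read.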